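Removing the Ring Hydroxy from a Fused Acylguanidine

The source may report more compounds than this note shows. Statements on the series, on what has been measured and on what is new or still open speak of the compounds shown alone.

Compound 1 `Cc1cc2c(cc1C(=O)N=C(N)N)S(=O)(=O)CC2N` gives 116 nM in an assay on cells for inhibition of sodium/hydrogen exchanger (Oryctolagus cuniculus); a higher number here means a weaker inhibitor, a lower number a stronger inhibitor. Compound 2 `Cc1cc2c(cc1C(=O)N=C(N)N)S(=O)(=O)CC2O` gives 70 nM in this assay.

Compound 2 holds the lowest of the two numbers, with compound 1 nearest; the step of a 1.7-fold lower number from compound 1 to compound 2 (0.22 log units; within the scatter) lies within the scatter. Compound 3 `Cc1cc2c(cc1C(=O)N=C(N)N)S(=O)(=O)CC2` differs from compound 2 by hydrogen in place of hydroxy on a saturated ring carbon. Among the measured compounds shown here, the only measured step, a 1.7-fold lower number from compound 1 to compound 2 (0.22 log units; within the scatter), replaces one group with another and stays within the scatter; no measured step removes the group outright. The expected step in this assay is therefore small, a 1.7-fold higher number from compound 2 to compound 3 (0.23 log units; within the scatter), with no direction beyond the scatter. Compound 3 is estimated at 120 nM, within 40 nM to 350 nM.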

Compound 3, half-maximal inhibitory concentration: 60 nM
Compound 3: the middle estimate sits 2.0-fold (0.30 log units) above what was measured, within the range that was stated.
By their numbers in this assay, from the lowest: compounds 3, 2 and 1 (each within the scatter of the next).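

Taking the hydroxy off this saturated ring carbon altogether (a 1.2-fold lower number from compound 2 to compound 3 (0.07 log units; within the scatter)) stays within the scatter in this assay, so the earlier swap of one group for another now has a counterpart in which no group remains. Hydrogen in place of amino (a 1.9-fold lower number from compound 1 to compound 3 (0.29 log units; within the scatter)) also stays within the scatter, so hydrogen, hydroxy and amino at this carbon cannot be told apart here. Nothing available explains this result. Still open, going by these compounds, is whether a carboxylic acid, a methoxy group or a longer chain on this carbon would give a step beyond the scatter.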